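Replacing methoxy with pyrrolidin-1-yl in compound 3

The compounds below may be only part of what the source reports. "The series", "measured", "known", "first", "only" and "open" are said of these compounds alone.

In a toxicity assay on microsomes from liver (Homo sapiens) for metabolic stability, read by LC-MS, using NADPH, tested at 1 uM (a higher number here means faster removal of the compound, a lower number slower removal), compound 3 `COc1ncc(-c2nc(C(F)(F)F)sc2N2CCN(C(=O)Cn3nc(C)nc3C)[C@H](C)C2)cn1` stands at < 10 mL.min-1.g-1, which is a limit of the assay and not a number. Elsewhere in the set, compound 1 `C[C@@H]1CN(c2scnc2-c2nc3ccccc3[nH]2)CCN1C(=O)Cn1cnc2cccnc21` gives 12 mL.min-1.g-1 and compound 2 `C[C@@H]1CN(c2sc(C3COC3)nc2-c2nc3ccccc3[nH]2)CCN1C(=O)Cn1cnc2cccnc21` gives 38 mL.min-1.g-1. Compound 4 `Cc1nc(C)n(CC(=O)N2CCN(c3sc(C(F)(F)F)nc3-c3cnc(N4CCCC4)nc3)C[C@H]2C)n1` differs from compound 3 by one change, pyrrolidin-1-yl in place of methoxy on an aromatic carbon. Within the data shown here, no measured step makes this same change. Among the measured compounds shown here, the only guide is a different one, oxetan-3-yl in place of hydrogen on an aromatic carbon, which gave a 3.2-fold higher number from compound 1 to compound 2 (0.50 log units; beyond the scatter), a modest step beyond the scatter. A similarly modest rise is therefore expected, an estimated at least 1.6-fold higher number from compound 3 to compound 4 (0.20 log units; that floor lies within the scatter). For compound 4 the expected value is 16 mL.min-1.g-1, within an estimated range of 7 mL.min-1.g-1 to 40 mL.min-1.g-1.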

Compound 4, intrinsic clearance in microsomes: 338 mL.min-1.g-1
Estimate against measurement, compound 4: 21-fold (1.32 log units) below; the whole stated range lies below it.
By their numbers in this assay, from the lowest: compound 1; then compound 2; then compound 4. At a limit, below all of these: compound 3.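

In this assay, the place between two ring nitrogen atoms proves highly sensitive to what sits on it: pyrrolidin-1-yl in place of methoxy gives an at least 33-fold higher number from compound 3 to compound 4 (1.52 log units; beyond the scatter). That is a much larger step than the only earlier one, a 3.2-fold higher number from compound 1 to compound 2 (0.50 log units; beyond the scatter), which was made on a different ring. Compound 3 stands at a limit, so the step is only a floor: the limit of < 10 mL.min-1.g-1 in this assay, at which 1 of the 4 values shown sits.

Still open, going by these compounds, is whether the ring of pyrrolidin-1-yl matters or only its attached nitrogen. An open-chain amine such as dimethylamino, or morpholin-4-yl, at this place would help separate the two.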